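A few compounds are considered here, and "the series" means these few. Any claim that something is new, unique, unknown or untested is made for them only; others in the source may bear on it.

Measured compounds:

Compound 1, `C=CCn1c(=O)/c(=C\c2cccc(Cl)c2Cl)[nH]c(=O)/c1=C\c1ccccc1OC`: 1200 nM
Compound 2, `C=CCn1c(=O)/c(=C\c2cccc(Br)c2)[nH]c(=O)/c1=C\c1ccccc1OC`: 2300 nM

Of the two numbers in hand from a functional assay on Huh-7 cells (Homo sapiens) for cytotoxicity, read by CCK-8 assay, with a stated time of 72 h (a lower number here means a stronger inhibitor, a higher number a weaker inhibitor), compound 2 holds the higher one, and its nearest neighbour is compound 1. Going by the values given here, the single step between them, a 1.9-fold higher number from compound 1 to compound 2 (0.28 log units; within the scatter), is a swap of 3-bromophenyl for 2,3-dichlorophenyl on a double-bonded chain carbon bound to an aromatic carbon, and it is within the scatter, so the two compounds cannot be told apart on these data.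

Compound 3, `C=CCn1c(=O)/c(=C\c2ccc(C)cc2)[nH]c(=O)/c1=C\c1ccccc1OC`, differs from compound 2 in the same place: 4-methylphenyl in place of 3-bromophenyl on a double-bonded chain carbon bound to an aromatic carbon. Among the compounds with values here, no measured step exchanges a bromine-bearing phenyl for a methyl-bearing one, so the only guidance is that the one exchange of one substituted phenyl for another at this position, a 1.9-fold higher number from compound 1 to compound 2 (0.28 log units; within the scatter), moved the number by less than the scatter. The expectation is therefore a change of similar size, with no clear direction beyond the scatter: a 1.1-fold higher number from compound 2 to compound 3 (0.04 log units; within the scatter) is expected. Compound 3 is accordingly estimated at 2500 nM in this assay, with a range from 900 nM to 7000 nM.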

Compound 3, half-maximal inhibitory concentration: "not active" (no number reported)
Compound 3: no number reported, so the estimate cannot be set against anything.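

In this assay, going by these compounds alone, compound 3 is reported only as "not active", with no number, so no step from compound 2 to compound 3 can be read. No measured evidence here bears on this result. The compounds shown leave open how 4-methylphenyl in place of 3-bromophenyl would compare numerically in this assay.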